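Swapping the amide heterocycle on an inactive triazole acetamide

The source may hold more compounds than are shown below. What is called first, only, known or untested is meant among the compounds shown, and "the series" means these compounds.

Compound 1 `Nc1cccc(-c2cn(CC(=O)Nc3nccs3)nn2)c1` gives 1270 nM in a functional assay on BMDM cells (Mus musculus, strain C57BL/6) for inhibition, with a stated time of 2 days; on this read-out higher numbers stand for weaker inhibition and lower numbers for stronger inhibition.
Compound 2 `Cc1cc(NC(=O)Cn2cc(-c3ccc(F)cc3)nn2)no1` gives only a limit, > 30000 nM, in this assay.
Compound 3 `O=C(Cn1cc(-c2cccs2)nn1)Nc1nccs1` gives only a limit, > 30000 nM, in this assay.

Compound 3 therefore stands at the assay's ceiling, sharing it with compound 2 (the limit of > 30000 nM in this assay, at which 2 of the 3 values shown sit). Within the data shown here, the one measured step, an at least 23-fold higher number from compound 1 to compound 3 (1.37 log units; beyond the scatter), concerns the group on the aromatic carbon, not the amide nitrogen, so it does not speak to the change now considered. Compound 4 `Cc1cc(NC(=O)Cn2cc(-c3cccs3)nn2)no1` differs from compound 3 by 5-methyl-1,2-oxazol-3-yl in place of 1,3-thiazol-2-yl on an amide-type nitrogen. Compound 2 already carries the entering group and shows only a limit, so no step beyond the scatter is expected and compound 4 is estimated at 40000 nM (range 15000 nM to 100000 nM), meaning an expected step that the limit leaves unreadable from compound 3 to compound 4.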

Compound 4, half-maximal inhibitory concentration: > 30000 nM
Compound 4 was reported as a limit (the forecaster's own chance of this, stated with the estimate: 85%); the middle value does not contradict the limit.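

Compound 4 also gives only a limit, > 30000 nM, in this assay, so its steps from compound 2 and compound 3 cannot be read. On these data alone, whether 5-methyl-1,2-oxazol-3-yl and 1,3-thiazol-2-yl differ at all on an amide-type nitrogen stays open.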